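Moving the Chloro Group Around the Aromatic Ring

The source may hold more compounds than are shown below. What is called first, only, known or untested is meant among the compounds shown, and "the series" means these compounds.

Two measured compounds share one core and differ only on the aromatic ring attached to the sulfonamide nitrogen. Compound 1 `CCOC(=O)C1=CCCCC1S(=O)(=O)Nc1ccccc1` carries a plain phenyl there, and in a functional assay on RAW264.7 cells (Mus musculus) for inhibition (on this read-out higher numbers stand for weaker inhibition and lower numbers for stronger inhibition), compound 1 gives 260 nM. Compound 2 `CCOC(=O)C1=CCCCC1S(=O)(=O)Nc1ccccc1Cl` carries a chloro group on that ring, and in this assay compound 2 gives 12 nM. Of these two numbers, compound 1 stands highest, so it is the weaker inhibitor of the pair. The step of a 22-fold lower number from compound 1 to compound 2 (1.34 log units; beyond the scatter) shows that a single chloro group can sharpen inhibition considerably.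

Compound 3 `CCOC(=O)C1=CCCCC1S(=O)(=O)Nc1ccc(Cl)cc1` has not yet been measured. Relative to compound 1 it shows (chloro in place of hydrogen on an aromatic carbon). Going by the values given here, the only measured step that bears on this change is a 22-fold lower number from compound 1 to compound 2 (1.34 log units; beyond the scatter), but there the chloro group sat at a different place on the ring, so that step is only a rough guide. Among the compounds with values here, a lower number is expected for compound 3, though probably a smaller drop than the one seen for compound 2. Compound 3 is estimated at 80 nM, with a likely range from 20 nM to 300 nM. That estimate corresponds to an expected step of a 3.3-fold lower number from compound 1 to compound 3 (0.51 log units; beyond the scatter).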

Compound 3, half-maximal inhibitory concentration: 400 nM
The estimate for compound 3 lay 5.0-fold (0.70 log units) below the measured number; measured number outside the range, above it.
By their numbers in this assay, from the lowest: compound 2; then compounds 1 and 3 (each within the scatter of the next).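

Adding a chloro group to the ring does not by itself lower the number: with the chloro para to a large group, as in the 4-chlorophenyl of compound 3, the result is a 1.5-fold higher number from compound 1 to compound 3 (0.19 log units; within the scatter) in this assay, so this change leaves compound 3 level with the plain phenyl of compound 1. The sharper contrast lies between the two chlorinated compounds, where moving from the 2-chlorophenyl to the 4-chlorophenyl gives a 33-fold higher number from compound 2 to compound 3 (1.52 log units; beyond the scatter), so among these three compounds the strong inhibition belongs to the 2-chlorophenyl alone and depends on where the chloro group sits, not merely on its presence. Nothing available here explains why the place of the chloro group matters so much.

From the compounds shown here alone, it remains open whether a fluoro, methyl or methoxy group in the chloro group's place on the 2-chlorophenyl ring would keep the number as low as in compound 2, or whether this result is particular to chloro. Also open, going by these compounds, is whether the same preference for the 2-chlorophenyl would hold if a carboxylic acid replaced the ethyl ester on the shared core.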